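The compounds below may be only part of what the source reports. "The series", "measured", "known", "first", "only" and "open" are said of these compounds alone.

Three compounds of the series have been run in a functional assay on MDA-MB-231 cells (Homo sapiens) for cytotoxicity, read by MTT assay, with a stated time of 48 h; on this read-out lower numbers stand for stronger inhibition and higher numbers for weaker inhibition. Compound 1 `O=C(/C=C/c1ccc2c(c1)B(O)OC2)c1ccco1` gives 7300 nM. Compound 2 `O=C(/C=C/c1ccc2c(c1)B(O)OC2)c1cccs1` gives 4600 nM. Compound 3 `O=C(/C=C/c1ccc2c(c1)B(O)OC2)c1ccc(Cl)cc1` gives 7900 nM. Compound 2 holds the lowest of the three numbers, but both neighbours sit close to it: a 1.6-fold lower number from compound 1 to compound 2 (0.20 log units; within the scatter), and a 1.7-fold higher number from compound 2 to compound 3 (0.23 log units; within the scatter). The remaining pair behaves the same way, a 1.1-fold higher number from compound 1 to compound 3 (0.03 log units; within the scatter). None of these steps leaves the scatter, so the three groups on the carbonyl carbon are not separated by the data in hand.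

Compound 4 `O=C(/C=C/c1ccc2c(c1)B(O)OC2)c1ccc(I)cc1` is still to be measured. Its change from compound 2 is 4-iodophenyl in place of thiophen-2-yl on a carbonyl carbon. The step that bears most directly on it is the exchange of the same thiophen-2-yl for 4-chlorophenyl, a 1.7-fold higher number from compound 2 to compound 3 (0.23 log units; within the scatter), which stayed within the scatter; the exchange of furan-2-yl for 4-chlorophenyl, a 1.1-fold higher number from compound 1 to compound 3 (0.03 log units; within the scatter), did likewise. A halogen-bearing phenyl on this carbonyl carbon has so far returned numbers the assay cannot tell from the heteroaryl ones. For compound 4 the expected step is therefore a 1.4-fold higher number from compound 2 to compound 4 (0.15 log units; within the scatter), nothing beyond the scatter. Compound 4 is estimated at 6500 nM, with a range from 3000 nM to 14000 nM.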

Compound 4, half-maximal inhibitory concentration: 14900 nM
Beside the measured number, compound 4's estimate is 2.3-fold (0.36 log units) below it, and the stated range ends below it.
By their numbers in this assay, from the lowest: compounds 2, 1, 3 and 4 (each within the scatter of the next, the first and the last beyond it).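

The carbonyl carbon now shows its first steps beyond the scatter in this assay: 4-iodophenyl in place of thiophen-2-yl gives a 3.2-fold higher number from compound 2 to compound 4 (0.51 log units; beyond the scatter), and 4-iodophenyl in place of furan-2-yl gives a 2.0-fold higher number from compound 1 to compound 4 (0.31 log units; beyond the scatter), so the group at this position can shift the read-out, though only modestly so far. Iodo in place of chloro on an aromatic carbon gives a 1.9-fold higher number from compound 3 to compound 4 (0.28 log units; within the scatter), which leaves the two halogens unresolved, and compound 3 goes against any clean split of halogen-bearing phenyl from heteroaryl groups, as its steps to compound 1 and compound 2 stay within the scatter. No measurement in hand accounts for the separation seen with the 4-iodophenyl group.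

Going by these compounds, it remains open whether a phenyl without a halogen, or a phenyl carrying an amine or a carboxylic acid in place of the iodo, would extend this separation or reverse it. On these data alone, it also remains open whether the same exchanges on the carbonyl carbon would give steps of similar size on a different core.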